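Lengthening an Ester Chain by One Carbon

This account rests on a few compounds, and the source may have more. Where it says the series, first, only, none or still open, it means among the compounds named here.

Compound 1 `NC(=O)CCCC/C=C(\c1ccccc1)c1cccnc1` and compound 2 `COC(=O)CCCC/C=C(\c1ccccc1)c1cccnc1` share one core. In a functional assay on the whole organism for inhibition, with Rattus norvegicus as the target, with a stated time of 2 h, at a dose of 10 mg/kg by the oral route (on this read-out lower numbers stand for less inhibition and higher numbers for more inhibition at the one dose given (going by the name of the read-out)), compound 1 gives 93%, and compound 2 gives 92%; the step of a number 1 percentage points lower from compound 1 to compound 2 (within the scatter) lies within the scatter, so on these two numbers compound 2 stands level with compound 1. Compound 3 `CCOC(=O)CCCC/C=C(\c1ccccc1)c1cccnc1` differs from compound 2 by methyl in place of hydrogen on a saturated chain carbon bound to an oxygen next to a carbonyl group. Going by the values given here, no measured step touches this place; the only step, a number 1 percentage points lower from compound 1 to compound 2 (within the scatter), changed the carbonyl substituent and stayed within the scatter, so no change beyond the scatter is expected in this assay. Compound 3 is expected to give 92%, between 82% and 98%. This means an expected step of no change at the digits printed from compound 2 to compound 3 (within the scatter).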

Compound 3, a percentage reported as inhibition, in the whole organism at one dose (the size of the read-out at that dose, not a potency): 90%
Beside the measured number, compound 3's estimate is 2 percentage points above it, and the stated range covers the measured number.
By their numbers in this assay, from the lowest: compounds 3, 2 and 1 (each within the scatter of the next).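

In this assay, going from methoxycarbonyl to ethoxycarbonyl gives a number 2 percentage points lower from compound 2 to compound 3 (within the scatter), so a methyl group at this place on the ester, a place the earlier step did not touch, leaves the read-out level. Ethoxy in place of amino on the carbonyl carbon gives a number 3 percentage points lower from compound 1 to compound 3 (within the scatter), so the amide and both esters all stand level at this one dose. Nothing available explains why these numbers stay level. Still open, on these data alone, is whether a longer chain on the ester oxygen, or a carboxylic acid in place of the ester, would stay level too.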